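Benzoyl for phenylsulfamoyl on the ring nitrogen

A few compounds are considered here, and "the series" means these few. Any claim that something is new, unique, unknown or untested is made for them only; others in the source may bear on it.

Three compounds of this series have numbers in an assay on tissue (HeLa cells) for inhibition of Indoleamine 2,3-dioxygenase 1 (Homo sapiens), with a stated time of 48 h; on this read-out lower numbers stand for stronger inhibition and higher numbers for weaker inhibition. Compound 1 `NS(=O)(=O)N1CCC(C(=O)/C(=N/O)Nc2ccc(F)c(Br)c2)CC1` gives 45 nM in this assay, compound 2 `O=C(/C(=N/O)Nc1ccc(F)c(Br)c1)C1CCN(C(=O)Nc2ccccc2)CC1` gives 54 nM, and compound 3 `O=C(/C(=N/O)Nc1ccc(F)c(Br)c1)C1CCN(S(=O)(=O)Nc2ccccc2)CC1` gives 150 nM. Compound 3 stands highest of the three: the steps were a 2.8-fold higher number from compound 2 to compound 3 (0.44 log units; beyond the scatter) and a 3.3-fold higher number from compound 1 to compound 3 (0.52 log units; beyond the scatter), while the step of a 1.2-fold higher number from compound 1 to compound 2 (0.08 log units; within the scatter) stayed within the scatter.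

Compound 4 `O=C(/C(=N/O)Nc1ccc(F)c(Br)c1)C1CCN(C(=O)c2ccccc2)CC1` carries the change (benzoyl in place of phenylsulfamoyl on an amine nitrogen in a ring). Among the measured compounds shown here, two measured steps bear on it. The step of a 2.8-fold higher number from compound 2 to compound 3 (0.44 log units; beyond the scatter) shows that replacing a carbonyl-linked phenyl group with a sulfonyl-linked one raised the number; the step of a 3.3-fold higher number from compound 1 to compound 3 (0.52 log units; beyond the scatter) shows that adding the phenyl on the sulfonamide nitrogen raised it as well. Compound 4 returns to a carbonyl linkage and drops the sulfonamide hydrogen, so a step back downward, of roughly the size seen between compound 2 and compound 3, is expected: a 2.1-fold lower number from compound 3 to compound 4 (0.33 log units; beyond the scatter). Compound 4 is therefore estimated at 70 nM in this assay, with a range of 30 nM to 170 nM, because compound 2 gives 54 nM with the same carbonyl attachment.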

Compound 4, half-maximal inhibitory concentration: 281 nM
Compound 4: the middle estimate sits 4.0-fold (0.60 log units) below what was measured; the measured number lies above the stated range.
By their numbers in this assay, from the lowest: compounds 1 and 2 (each within the scatter of the next); then compounds 3 and 4 (each within the scatter of the next).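

In this assay the carbonyl attachment alone does not go with the low number of compound 2: phenyl in place of anilino on a carbonyl carbon gives a 5.2-fold higher number from compound 2 to compound 4 (0.72 log units; beyond the scatter), so the anilino group matters at this position. Benzoyl in place of phenylsulfamoyl gives a 1.9-fold higher number from compound 3 to compound 4 (0.27 log units; within the scatter), which cannot be told from the scatter, while benzoyl in place of sulfamoyl gives a 6.2-fold higher number from compound 1 to compound 4 (0.80 log units; beyond the scatter), the largest step among these compounds. No measurement on hand accounts for these steps.

Open, on these data alone, is whether a phenylacetyl group, with a methylene in place of the anilino nitrogen, would stand with compound 2 or with compound 4. Also open, as far as these compounds go, is whether a methyl on the anilino nitrogen would keep the number of compound 2.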